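A few compounds are considered here, and "the series" means these few. Any claim that something is new, unique, unknown or untested is made for them only; others in the source may bear on it.

Measured compounds:

Compound 1, `CC1=C(/C=C/C(=O)/C=C/c2cccc(C(F)(F)F)c2)C(C)(C)CCC1`: 7700 nM
Compound 2, `CC1=C(/C=C/C(=O)/C=C/c2cc(C(F)(F)F)cc(C(F)(F)F)c2)C(C)(C)CCC1`: 7200 nM
Compound 3, `CC1=CCCC(C)(C)C1/C=C/C(=O)/C=C/c1ccccc1F`: 4800 nM

All three were tested in a functional assay on PC-3 cells (Homo sapiens) for cytotoxicity, read by MTT assay, with a stated time of 72 h; on this read-out lower numbers stand for stronger inhibition and higher numbers for weaker inhibition. Compound 1 gives 7700 nM, and compound 2, which carries the change (trifluoromethyl in place of hydrogen on an aromatic carbon), gives 7200 nM; the step between them is a 1.1-fold lower number from compound 1 to compound 2 (0.03 log units; within the scatter). Compound 3 gives 4800 nM in this assay; its number is the lowest of the three, but its gaps to compound 2 and to compound 1 both lie within the scatter, so no order among the three can be claimed. The difference between the core of compound 3 and the core of compound 1 is not broken down here.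

Compound 4, `CC1=CCCC(C)(C)C1/C=C/C(=O)/C=C/c1cc(C(F)(F)F)ccc1F`, is not yet measured. It carries the change trifluoromethyl in place of hydrogen on an aromatic carbon relative to compound 3. Among the compounds with values here, this is the same kind of change as the one from compound 1 to compound 2, though the surroundings differ: in compound 4 the entering group is para to a fluoro group, whereas in compound 2 it is meta to a trifluoromethyl group.

Compound 4 is expected to give about 4500 nM in this assay, with a likely range from 2000 nM to 10000 nM. The expected step is a 1.1-fold lower number from compound 3 to compound 4 (0.03 log units; within the scatter), essentially flat. This expectation rests on compound 1 and compound 2, whose step a 1.1-fold lower number from compound 1 to compound 2 (0.03 log units; within the scatter) was within the scatter, and on the value of compound 3, 4800 nM, as the starting point.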

Compound 4, half-maximal inhibitory concentration: 3100 nM
The estimate for compound 4 lay 1.5-fold (0.16 log units) above the measured number; measured number inside the range.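

In this assay, trifluoromethyl in place of hydrogen on an aromatic carbon gives a 1.5-fold lower number from compound 3 to compound 4 (0.19 log units; within the scatter), so this step, like the earlier one, cannot be told from the scatter. Set side by side, the two steps do not differ, and the change can be said to carry over from one core to the other as far as these measurements can resolve: the same change on two cores in this assay, a 1.1-fold lower number (0.03 log units; within the scatter) from compound 1 to compound 2 and a 1.5-fold lower number (0.19 log units; within the scatter) from compound 3 to compound 4, 1.4-fold (0.16 log units) apart, within the scatter of two such steps. Within the data shown here, this shows only that neither core gives a step beyond the scatter; it does not show that the change has no effect at all, and two pairs, in which the entering group has different surroundings, cannot establish a rule for other cores.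

The compounds shown leave open what other groups would do on the aromatic ring, such as a nitrile, a methoxy group or an amine, as only fluoro and trifluoromethyl appear there as substituents. The contribution of the core itself also stays open, as no pair shown differs in the core alone, so the difference between the core of compound 3 and the core of compound 1 cannot be read from these data.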